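Thiophen-3-yl for thiophen-2-yl, compound 3 to compound 4

This account rests on a few compounds, and the source may have more. Where it says the series, first, only, none or still open, it means among the compounds named here.

Compound 1 `CSc1ncnc2c1c(-c1ccsc1)cn2[C@@H]1O[C@H](CO)[C@@H](O)[C@H]1O` gives 95800 nM
Compound 2 `CNc1ncnc2c1c(-c1ccsc1)cn2[C@@H]1O[C@H](CO)[C@@H](O)[C@H]1O` gives > 100000 nM (a limit)
Compound 3 `Cc1ncnc2c1c(-c1cccs1)cn2[C@@H]1O[C@H](CO)[C@@H](O)[C@H]1O` gives > 100000 nM (a limit)

In an ADME assay on BJ cells (Homo sapiens), read by MTT assay, with a stated time of 72 h (on this read-out higher numbers stand for weaker inhibition and lower numbers for stronger inhibition), compound 3 gives > 100000 nM as a limit and not a number. Compound 3 thus stands at the limit of > 100000 nM in this assay, at which 2 of the 3 values shown sit, in these data. Compound 4 `Cc1ncnc2c1c(-c1ccsc1)cn2[C@@H]1O[C@H](CO)[C@@H](O)[C@H]1O` has thiophen-3-yl in place of thiophen-2-yl on an aromatic carbon, the same atoms joined differently. Among the compounds with values here, no measured step makes this swap. Within the data shown here, the only measured step, an at least 1.0-fold higher number from compound 1 to compound 2 (0.01 log units; that floor lies within the scatter) (a change of another group), stays within the scatter. Compound 1, which also carries thiophen-3-yl, reads 95800 nM in this assay and so no change beyond the scatter is expected. The expected step is a number no higher from compound 3 to compound 4 (the limit leaves the size open) in this assay with no clear direction. Compound 4 is estimated at 100000 nM with an expected range from 50000 nM to 200000 nM in this estimate.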

Compound 4, half-maximal inhibitory concentration: 96900 nM
Compound 4: the middle estimate sits 1.0-fold (0.01 log units) above what was measured; the measured number falls inside the stated range.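

In this assay the swap gives an at least 1.0-fold lower number from compound 3 to compound 4 (0.01 log units; that floor lies within the scatter) at this position, so moving from thiophen-2-yl to thiophen-3-yl shows no change that can be told from the scatter. With thiophen-3-yl held fixed, methyl on an aromatic carbon gives an at least 1.0-fold lower number from compound 2 to compound 4 (0.01 log units; that floor lies within the scatter) and a 1.0-fold higher number from compound 1 to compound 4 (0.00 log units; within the scatter) and so also shows no change that can be told from the scatter. From the compounds shown here alone, whether an amine or a carboxylic acid on the thiophene would move the number remains open. The true size of the steps from compound 2 and compound 3 also stays open, since each starts from a limit and not a number: the limit of > 100000 nM in this assay, at which 2 of the 4 values shown sit.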